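Aryl amino series: cytotoxicity working notes

This account rests on a few compounds, and the source may have more. Where it says the series, first, only, none or still open, it means among the compounds named here.

Measured compounds:
- Compound 1 `Cc1nc(Nc2ccc(Cl)c(Cl)c2)sc1C(=O)/C=C/c1ccccc1`: in a functional assay on Bel-7402 cells (Homo sapiens) for cytotoxicity, read by MTT assay (on this read-out lower numbers stand for stronger inhibition and higher numbers for weaker inhibition), compound 1 gives 21500 nM.
- Compound 2 `Cc1cccc(Nc2nc(C)c(C(=O)/C=C/c3ccccc3)s2)c1`: in this assay compound 2 gives > 25000 nM, which is a limit of the assay and not a number.
- Compound 3 `Cc1nc(Nc2ccc(Cl)c(Cl)c2)sc1C(=O)/C=C/c1ccc(Cl)cc1`: in this assay compound 3 gives > 25000 nM, which is also a limit of the assay and not a number.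

Compound 2 differs from compound 1 by 3-methylphenyl in place of 3,4-dichlorophenyl on a nitrogen on an aromatic ring. That change gives an at least 1.1-fold higher number from compound 1 to compound 2 (0.06 log units; that floor lies within the scatter), a floor that rests on (the limit of > 25000 nM in this assay, at which 2 of the 3 values shown sit). Compound 3 differs from compound 1 by chloro in place of hydrogen on an aromatic carbon. Here the step is an at least 1.1-fold higher number from compound 1 to compound 3 (0.06 log units; that floor lies within the scatter), again resting on (the limit of > 25000 nM in this assay, at which 2 of the 3 values shown sit). None of the three compounds can be ordered against the others beyond these floors.

Compound 4 `Cc1cccc(Nc2nc(C)c(C(=O)/C=C/c3ccc(Cl)cc3)s2)c1` has not yet been measured in this assay. Among the compounds with values here, it differs from compound 3 by 3-methylphenyl in place of 3,4-dichlorophenyl on a nitrogen on an aromatic ring, the same change as the one from compound 1 to compound 2, made on a core that differs from the core of compound 1 by chloro in place of hydrogen on an aromatic carbon; the place of the change is the same in both pairs. Compound 4 is expected to move by a step that the limit leaves unreadable from compound 3 to compound 4 only, because the same change earlier gave an at least 1.1-fold higher number from compound 1 to compound 2 (0.06 log units; that floor lies within the scatter). Compound 3 already sits at the limit of > 25000 nM in this assay, at which 2 of the 3 values shown sit. The estimate for compound 4 in this assay is therefore 40000 nM, expected to fall between 20000 nM and 120000 nM, and most likely to be reported only as a limit rather than a number.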

Compound 4, half-maximal inhibitory concentration: > 25000 nM
Compound 4: only a limit was reported (the forecaster's own chance of this, stated with the estimate: 85%); the middle value is on the limit's open side.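

No new step can be read from compound 4: in this assay compound 2, compound 3 and compound 4 all stand at a limit and not a number, so the steps from compound 3 and from compound 2 to compound 4 cannot be read: the limit of > 25000 nM in this assay, at which 3 of the 4 values shown sit.

The compounds shown leave open whether 3-methylphenyl in place of 3,4-dichlorophenyl, or chloro in place of hydrogen, changes the cytotoxicity on either core.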